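Trimming the Side-Chain Amine: Compound 3 to Compound 4

The compounds below may be only part of what the source reports. "The series", "measured", "known", "first", "only" and "open" are said of these compounds alone.

In an ADME assay on J774 cells (Mus musculus) for cytotoxicity, read by MTT assay, with a stated time of 48 h (on this read-out lower numbers stand for stronger inhibition and higher numbers for weaker inhibition), compound 1 `CC(C)(C)OC(=O)NCCNc1cc(/C=C/c2ccccc2)nc2ccccc12` gives 6600 nM, compound 2 `CN(C)CC(=O)NCCNc1cc(/C=C/c2ccccc2)nc2ccccc12` gives 15000 nM and compound 3 `O=C(CN1CCN(c2ccccc2)CC1)NCCNc1cc(/C=C/c2ccccc2)nc2ccccc12` gives 4500 nM. Compound 3 holds the lowest number of the three; its gap to compound 1 lies within the scatter, while a 3.3-fold lower number from compound 2 to compound 3 (0.52 log units; beyond the scatter). Compound 4 `O=C(CNc1ccccc1)NCCNc1cc(/C=C/c2ccccc2)nc2ccccc12` differs from compound 3 by anilino in place of 4-phenylpiperazin-1-yl on a saturated chain carbon bound to a carbonyl carbon. Among the measured compounds shown here, of the measured steps, only the one from compound 2 to compound 3 touches this place, since a 2.3-fold higher number from compound 1 to compound 2 (0.36 log units; beyond the scatter) concerns the carbonyl substituent. Because a 3.3-fold lower number from compound 2 to compound 3 (0.52 log units; beyond the scatter) accompanied the arrival of the 4-phenylpiperazin-1-yl group, removing part of it is expected to give back some of that, a modest rise in this assay, a 1.7-fold higher number from compound 3 to compound 4 (0.22 log units; within the scatter). Compound 4 is therefore estimated at 7500 nM, within 3000 nM to 18000 nM.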

Compound 4, half-maximal inhibitory concentration: 7800 nM
Estimate against measurement, compound 4: 1.0-fold (0.02 log units) below; the range from low to high includes it.
By their numbers in this assay, from the lowest: compounds 3, 1, 4 and 2 (each within the scatter of the next, the first and the last beyond it).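

At this saturated chain carbon in this assay, anilino stands within the scatter of both earlier groups, with a 1.7-fold higher number from compound 3 to compound 4 (0.24 log units; within the scatter) and a 1.9-fold lower number from compound 2 to compound 4 (0.28 log units; within the scatter), even though 4-phenylpiperazin-1-yl and dimethylamino lie beyond the scatter of each other. Read as anilinomethyl in place of tert-butoxy on a carbonyl carbon, the change also stays within the scatter, with a 1.2-fold higher number from compound 1 to compound 4 (0.07 log units; within the scatter). Nothing at hand explains these numbers. Going by these compounds, whether a morpholine or piperidine ring at this place, or a chlorine on the anilino ring, would give a step beyond the scatter stays open.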